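From pyrazole to methyl-triazole on the shared core

The source may hold more compounds than are shown below. What is called first, only, known or untested is meant among the compounds shown, and "the series" means these compounds.

Of the compounds shown here, three sharing one core have been measured in a functional assay with Alpha-1A adrenergic receptor (Homo sapiens) as the target, read by calcium flux; on this read-out higher numbers stand for larger maximal responses and lower numbers for smaller maximal responses. Compound 1 `CCn1ncnc1-c1ccccc1NCC1=NCCN1` gives 107%. Compound 2 `CCCCn1ncnc1-c1ccccc1NCC1=NCCN1` gives 86%. Compound 3 `Cn1cc(-c2ccccc2NCC2=NCCN2)cn1` gives 39%, the lowest of the three numbers, with compound 2 the nearest and compound 1 the furthest, both beyond the scatter.

Compound 4 `Cn1ncnc1-c1ccccc1NCC1=NCCN1` is not yet measured. It differs from compound 3 by 1-methyl-1H-1,2,4-triazol-5-yl in place of 1-methyl-1H-pyrazol-4-yl on an aromatic carbon. Among the compounds with values here, the only measured step, a number 21 percentage points lower from compound 1 to compound 2 (beyond the scatter), concerns lengthening the chain on the aromatic nitrogen of the same five-membered ring that compound 4 carries; it does not test the swap of the ring itself. What the numbers show is that both compounds bearing a 1-alkyl-1,2,4-triazol-5-yl group, compound 1 and compound 2, sit far above compound 3. Compound 4, with the shortest such chain, is therefore expected to land close to compound 1, a rise estimated at a number 61 percentage points higher from compound 3 to compound 4 (beyond the scatter) in this assay. Compound 4 is estimated at 100%, within a range from 75% to 125%.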

Compound 4, largest response reached (reported as maximal response), in percent of the reference or control that the assay uses: 91%
Estimate against measurement, compound 4: 9 percentage points above; the range from low to high includes it.
By their numbers in this assay, from the lowest: compound 3; then compounds 2 and 4 (each within the scatter of the next); then compound 1.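

The ring itself turns out to matter at this position: on an aromatic carbon of the shared core, with the methyl kept and the heavy-atom count unchanged, 1-methyl-1H-1,2,4-triazol-5-yl in place of 1-methyl-1H-pyrazol-4-yl gives a number 52 percentage points higher from compound 3 to compound 4 (beyond the scatter) in this assay as the result of this one change. The chain on the triazole nitrogen now has three points, and they do not follow chain length in a single direction: the butyl-to-methyl change gives a number 5 percentage points higher from compound 2 to compound 4 (within the scatter) while the ethyl-to-methyl change gives a number 16 percentage points lower from compound 1 to compound 4 (beyond the scatter) so that ethyl alone stands apart. No measurement shown here explains these differences.

The swap changes the number of ring nitrogens and the ring's point of attachment together, and a 1-methyl-1H-pyrazol-5-yl group would help separate the two. Also open, going by these compounds, is how a propyl chain, or a chain ending in an amine, would read on the triazole nitrogen.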